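The source may report more compounds than this note shows. Statements on the series, on what has been measured and on what is new or still open speak of the compounds shown alone.

Compound 1 `CC1(C)C=C(n2ccccc2=O)c2cc(S(=O)(=O)N=[N+]=[N-])ccc2O1` is the starting point. For the measured compounds named here, in a functional assay with Rattus norvegicus as the target (a lower number here means that less compound is needed, a higher number that more compound is needed for the effect), compound 1 gives 204 nM, the highest of the two numbers measured so far. Going by the values given here, its only measured neighbour, compound 2 `CN(c1ccccc1)S(=O)(=O)c1ccc2c(c1)C(n1ccccc1=O)=CC(C)(C)O2`, gives 9.77 nM in this assay, and the step between them, a 21-fold lower number from compound 1 to compound 2 (1.32 log units; beyond the scatter), is the one change measured to date: methyl(phenyl)amino in place of azido on a sulfonyl sulfur. Compound 3 `CC1(C)C=C(n2ccccc2=O)c2cc(S(=O)(=O)NC(=O)Nc3ccccc3)ccc2O1` has not been measured yet. It differs from compound 1 as follows: (phenylcarbamoyl)amino in place of azido on a sulfonyl sulfur. Among the compounds with values here, the one step that bears on this change, a 21-fold lower number from compound 1 to compound 2 (1.32 log units; beyond the scatter), likewise replaced the azido on the sulfonyl sulfur with a group carrying a phenyl ring and was large, so a lower number is expected for compound 3 as well, though the (phenylcarbamoyl)amino group is different enough that a smaller step seems prudent. Compound 3 is therefore estimated at 40 nM, within 10 nM to 160 nM. That corresponds to an expected step of a 5.1-fold lower number from compound 1 to compound 3 (0.71 log units; beyond the scatter).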

Compound 3, half-maximal effective concentration: 10000 nM
The estimate for compound 3 lay 250-fold (2.40 log units) below the measured number; measured number outside the range, above it.
By their numbers in this assay, from the lowest: compound 2; then compound 1; then compound 3.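

A phenyl ring in the group on the sulfonyl sulfur does not by itself bring a lower number in this assay: compound 2 carries one and sits lowest, yet (phenylcarbamoyl)amino in place of azido gives a 49-fold higher number from compound 1 to compound 3 (1.69 log units; beyond the scatter), the opposite direction to the earlier step. Against the methyl(phenyl)amino group, the same replacement gives a 1000-fold higher number from compound 2 to compound 3 (3.01 log units; beyond the scatter), so the three compounds spread widely on this one place, and the identity of the whole group matters, not just the presence of the ring. Nothing available gives a reason for this reversal.

On these data alone, it remains open which part of (phenylcarbamoyl)amino goes with the high number: the carbonyl, the nitrogens or the phenyl ring. Also open, as far as these compounds go, is where a plain amino or dimethylamino group on the sulfonyl sulfur would fall in this assay.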